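Toxicity to prostate cancer cells after swapping one side group

This account rests on a few compounds, and the source may have more. Where it says the series, first, only, none or still open, it means among the compounds named here.

Compound 1 `O=C(Nc1cccc(Oc2ccccn2)c1)C1CCCN(C(=O)c2cc(C(F)(F)F)cc(C(F)(F)F)c2)C1` was tested in an ADME assay on PC-3 cells (Homo sapiens) for cytotoxicity, read by WST assay, tested at 100 uM (a higher number here means more inhibition at the concentration tested (going by the name of the read-out), a lower number less inhibition), where compound 1 gives 0%. In this assay compound 2 `Cc1nc(-c2cccc(C(=O)N3CCCC(C(=O)Nc4ccc(Cl)cc4)C3)c2)no1` gives 0%, so compound 1 stands level with compound 2 within the scatter. Compound 3 `O=C(Nc1cccc(CN2CCCC2)c1)C1CCCN(C(=O)c2cc(C(F)(F)F)cc(C(F)(F)F)c2)C1` is not yet measured. The change from compound 1 to compound 3 is (pyrrolidin-1-yl)methyl in place of (pyridin-2-yl)oxy on an aromatic carbon. Going by the values given here, both measured values sit at the floor of the read-out, and no step between measured compounds is known, so in this assay the expected step is a number 5 percentage points higher from compound 1 to compound 3 (within the scatter), none beyond the scatter. For compound 3 the estimated value is 5%, expected to lie between 0% and 25%.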

Compound 3, a percentage reported as inhibition, at one concentration (the size of the read-out at that concentration, not a potency): 51%
Compound 3: the middle estimate sits 46 percentage points below what was measured; measured number above the stated range.
By their numbers in this assay, from the lowest: compounds 1 and 2 (each within the scatter of the next); then compound 3.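

In this assay, (pyrrolidin-1-yl)methyl in place of (pyridin-2-yl)oxy on an aromatic carbon gives a large rise, with a number 51 percentage points higher from compound 1 to compound 3 (beyond the scatter) and a clear move off the floor of the read-out. Going by these compounds alone, this is the first sign that the group at this one place can change the result while the rest of compound 1 stays the same. Nothing measured here explains the rise.

Going by these compounds, it remains open whether the step depends on the amine nitrogen of the pyrrolidine ring or on the loss of the (pyridin-2-yl)oxy group. A dimethylaminomethyl group or a plain benzyl group at the same place could help separate these two readings.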